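This account rests on a few compounds, and the source may have more. Where it says the series, first, only, none or still open, it means among the compounds named here.

Measured so far in a physicochemical assay for lipophilicity; a lower number here means a more polar compound, a higher number a more lipophilic compound:
- compound 1 `CCN1C(=O)CN(Cc2ccc(-c3cccc(CN4CCCCC4)n3)cc2)C1=O`: 1.7
- compound 2 `CCN1C(=O)CN(Cc2ccc(-c3ccc(F)c(CN4CCCCC4)n3)cc2)C1=O`: 2.1

Compound 1 is the lower of the two, with 1.7. The next compound, compound 3 `CCN1C(=O)CN(Cc2ccc(-c3cccc(CC4CCCCC4)n3)cc2)C1=O`, has cyclohexyl in place of piperidin-1-yl on a saturated chain carbon bound to an aromatic carbon. A six-membered ring with a hetero atom thus gives way to a ring of carbon only.

Among the compounds with values here, only one measured step is available, a number 0.40 log units higher from compound 1 to compound 2 (beyond the scatter), and it is a different change: fluoro in place of hydrogen on an aromatic carbon. It leaves the piperidin-1-yl untouched, so it shows only that this assay moves measurably within this series and gives no direct size for the present swap. Within the data shown here, no measured pair covers that swap, so the estimate is loose.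

An upward move is expected, estimated as a number 2.40 log units higher from compound 1 to compound 3 (beyond the scatter), much larger than the fluoro step. For compound 3 the expected value is 4.1, with an estimated range of 3.3 to 4.9.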

Compound 3, distribution coefficient: 5.6
Compound 3: the middle estimate sits 1.50 log units below what was measured; measured number outside the range, above it.
By their numbers in this assay, from the lowest: compound 1; then compound 2; then compound 3.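

In this assay, the swap on a saturated chain carbon bound to an aromatic carbon gives a number 3.90 log units higher from compound 1 to compound 3 (beyond the scatter) and so far outweighs the fluoro change, which gives a number 0.40 log units higher from compound 1 to compound 2 (beyond the scatter) at a different place on the shared core. This position therefore carries the largest shift seen so far in the series. The two groups have the same heavy-atom count, and what separates them is the ring nitrogen of piperidin-1-yl, with its hydrogen-bond acceptor, against the ring of carbon only in cyclohexyl; nothing measured on these compounds explains the size of the step.

Still open, on these data alone, is how the number follows the ring atoms and ring size at this place, which a morpholin-4-yl, a pyrrolidin-1-yl or a 4-hydroxypiperidin-1-yl group would help to show. Also open, as far as these compounds go, are whether the fluoro step adds to the cyclohexyl swap when both sit on the same core, and whether an open-chain amine such as dimethylamino or a carboxylic acid on the chain carbon would bring the number back towards that of compound 1.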